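The source may hold more compounds than are shown below. What is called first, only, known or untested is meant among the compounds shown, and "the series" means these compounds.

In a functional assay on SW-620 cells (Homo sapiens) for antiproliferative activity, read by MTT assay, with a stated time of 24 h (on this read-out higher numbers stand for weaker inhibition and lower numbers for stronger inhibition), compound 1 `COc1ccc(C(=O)/C=C/c2ccc(Br)cc2)c2c1C=CC(C)(C)O2` gives > 10000 nM, which is a limit of the assay and not a number. Compound 2 `COc1ccc(C(=O)/C=C/c2ccc(N(C)C)cc2)c2c1C=CC(C)(C)O2` gives 570 nM, and compound 3 `CCN(CC)c1ccc(/C=C/C(=O)c2ccc(OC)c3c2OC(C)(C)C=C3)cc1` gives 670 nM, so these two stand level. Replacing bromo made large steps: an at least 17-fold lower number from compound 1 to compound 2 (1.24 log units; beyond the scatter) and an at least 14-fold lower number from compound 1 to compound 3 (1.17 log units; beyond the scatter). Compound 4 `COc1ccc(C(=O)/C=C/c2ccc(N3CCCC3)cc2)c2c1C=CC(C)(C)O2` differs from compound 3 in one place, with pyrrolidin-1-yl in place of diethylamino on an aromatic carbon. The closest guide is the exchange of one amino group for another, a 1.2-fold higher number from compound 2 to compound 3 (0.07 log units; within the scatter), which stays within the scatter. The expected change is a 1.1-fold lower number from compound 3 to compound 4 (0.05 log units; within the scatter), which means no step beyond the scatter is expected. For compound 4, the estimated value is 600 nM, with an expected range from 250 nM to 1500 nM.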

Compound 4, half-maximal inhibitory concentration: 7150 nM
Beside the measured number, compound 4's estimate is 12-fold (1.08 log units) below it, and the stated range ends below it.
By their numbers in this assay, from the lowest: compounds 2 and 3 (each within the scatter of the next); then compound 4. At a limit, above all of these: compound 1.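

In this assay, tying the chain into a ring matters at this position: pyrrolidin-1-yl has the same count of heavy atoms as diethylamino, yet the swap gives an 11-fold higher number from compound 3 to compound 4 (1.03 log units; beyond the scatter). Dimethylamino gives the same picture, with a 13-fold higher number from compound 2 to compound 4 (1.10 log units; beyond the scatter), so amino groups here are not interchangeable, as compound 2 and compound 3 alone suggested. Against bromo only a floor can be read, an at least 1.3-fold lower number from compound 1 to compound 4 (0.14 log units; that floor lies within the scatter), because compound 1 stands at a limit and not a number: the limit of > 10000 nM in this assay, at which 1 of the 4 values shown sits.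

On these data alone, whether a six-membered ring such as piperidin-1-yl or morpholin-4-yl behaves like pyrrolidin-1-yl stays open, as does a primary amine at this place. What lies behind the weaker inhibition of compound 4 also stays open.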